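Methyl to Fluoro on the Benzyl Ring: Expected Electroshock Dose

The source may report more compounds than this note shows. Statements on the series, on what has been measured and on what is new or still open speak of the compounds shown alone.

Compound 1, `Cc1nnc(NC(N)=O)cc1Cc1ccccc1`: 10.2 mg/kg
Compound 2, `Cc1nn2c(N)nnc2cc1Cc1ccccc1`: 22 mg/kg
Compound 3, `Cc1ccc(Cc2cc3nnc(N)n3nc2C)cc1`: 22.5 mg/kg

In a functional assay on the whole organism with Mus musculus as the target, in the maximal electroshock model (on this read-out higher numbers stand for an effect only at larger amounts of compound and lower numbers for an effect already at smaller amounts), compound 3 stands at the highest of the three numbers. Its nearest neighbour is compound 2: the step of a 1.0-fold higher number from compound 2 to compound 3 (0.01 log units; within the scatter) lies within the scatter, so the two cannot be told apart. The gap to compound 1, which gives the lowest number, lies beyond the scatter.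

Compound 4, `Cc1nn2c(N)nnc2cc1Cc1ccc(F)cc1`, differs from compound 3 by fluoro in place of methyl on an aromatic carbon. Going by the values given here, no measured pair exchanges methyl for fluoro, so nothing bears directly on this change. Among the compounds with values here, the only step that touches the same ring, a 1.0-fold higher number from compound 2 to compound 3 (0.01 log units; within the scatter), shows that adding methyl there did nothing beyond the scatter; the step in the other direction therefore gives no ground to expect movement from the fluoro either. Compound 4 is accordingly expected to give about 21 mg/kg, within a range from 10 mg/kg to 45 mg/kg. The estimated step of a 1.1-fold lower number from compound 3 to compound 4 (0.03 log units; within the scatter) is expected to stay within the scatter.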

Compound 4, dose for half-maximal effect: 43 mg/kg
Estimate against measurement, compound 4: 2.0-fold (0.31 log units) below; the range from low to high includes it.
By their numbers in this assay, from the lowest: compound 1; then compounds 2, 3 and 4 (each within the scatter of the next).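

In this assay, fluoro in place of methyl gives a 1.9-fold higher number from compound 3 to compound 4 (0.28 log units; within the scatter), and fluoro in place of hydrogen gives a 2.0-fold higher number from compound 2 to compound 4 (0.29 log units; within the scatter). The earlier compounds shown here had tested only methyl against hydrogen on this aromatic carbon, para to a large group; with fluoro as a second group there, hydrogen, methyl and fluoro still cannot be told apart on this read-out. Nothing available explains these numbers or shows what the exchange does beyond them.

The compounds shown leave open whether any group at this place would give a number beyond the scatter from compound 2, for instance an amine, a methoxy group or a carboxylic acid. They also leave open whether fluoro would behave alike on another carbon of the same ring.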